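Nitro Substitution on a Hydroxamic Acid Quinolone Core

The source may hold more compounds than are shown below. What is called first, only, known or untested is meant among the compounds shown, and "the series" means these compounds.

Compound 1, `CCCCCCCc1[nH]c2ccccc2c(=O)c1C(=O)O`: 15000 nM in a physicochemical assay for solubility, read by HPLC, at pH 7.4; a higher number here means a more soluble compound, a lower number a less soluble compound
Compound 2, `CCCCCCCc1[nH]c2ccc([N+](=O)[O-])cc2c(=O)c1C(=O)O`: 15000 nM in this assay
Compound 3, `CCCCCCCc1[nH]c2ccccc2c(=O)c1C(=O)NO`: > 200000 nM in this assay, which is a limit of the assay and not a number

The three measured compounds share the core of compound 1. Compound 2 differs from compound 1 by nitro in place of hydrogen on an aromatic carbon, and in this assay no change at the digits printed from compound 1 to compound 2 (within the scatter). Compound 3 differs from compound 1 by hydroxyamino in place of hydroxy on a carbonyl carbon, and here an at least 13-fold higher number from compound 1 to compound 3 (1.12 log units; beyond the scatter). Compound 3 stands at the limit of > 200000 nM in this assay, at which 1 of the 3 values shown sits, so for compound 3 only a limit is known, not a number.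

Compound 4, `CCCCCCCc1[nH]c2ccc([N+](=O)[O-])cc2c(=O)c1C(=O)NO`, has not yet been measured in this assay. It differs from compound 3 by nitro in place of hydrogen on an aromatic carbon, the same change as that from compound 1 to compound 2, on the same place of the same core. Because no change at the digits printed from compound 1 to compound 2 (within the scatter), the same change is expected to leave the value of compound 4 close to that of compound 3, and the step that the limit leaves unreadable from compound 3 to compound 4 is the estimated outcome. For compound 4 the solubility in this assay is therefore expected at about 250000 nM, with a range estimated from 80000 nM to 600000 nM, and a high chance that the assay again reports only a limit rather than a number.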

Compound 4, solubility: > 200000 nM
Compound 4: no number, only a limit; the forecaster's own chance of this, stated with the estimate: 70%; the middle value does not contradict the limit.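

In this assay the nitro change cannot be followed onto the second core, since compound 3 and compound 4 both give a limit of the assay and not a number, and the step between them cannot be read: the limit of > 200000 nM in this assay, at which 2 of the 4 values shown sit.

What can be read is the other change carried across: with the nitro group present, hydroxyamino in place of hydroxy on a carbonyl carbon gives an at least 13-fold higher number from compound 2 to compound 4 (1.12 log units; beyond the scatter), which matches in direction and printed size the step without it, an at least 13-fold higher number from compound 1 to compound 3 (1.12 log units; beyond the scatter). As far as these compounds go, this does not show that nitro is as silent on the second core as it is on the first, where the record is no change at the digits printed from compound 1 to compound 2 (within the scatter), and as both hydroxyamino steps end at a limit, their true sizes remain unknown.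

The compounds shown leave open where compound 3 and compound 4 lie relative to each other, which only readings that do not stop at the limit could settle. They also leave open what a group other than nitro, such as an amine or a chlorine atom, would do on that aromatic carbon, and what a longer chain would do on either core.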